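A few compounds are considered here, and "the series" means these few. Any claim that something is new, unique, unknown or untested is made for them only; others in the source may bear on it.

Measured compounds:
compound 1 `CCCNc1nc2ccc(-c3cnc(Cl)c(NS(=O)(=O)c4ccc(F)cc4)c3)cc2s1` — "not determined" (no result reported) in a functional assay on A549 cells (Homo sapiens) for antiproliferative activity, read by MTT assay, with a stated time of 72 h; a higher number here means a weaker inhibitor, a lower number a stronger inhibitor
compound 2 `CNC(=O)Nc1nc2ccc(-c3cnc(OC)c(NS(=O)(=O)c4ccc(F)cc4)c3)cc2s1` — 1560 nM
compound 3 `COc1ncc(-c2ccc3nc(NC(=O)NCCN(C)C)sc3c2)cc1NS(=O)(=O)c1ccc(F)cc1` — 470 nM

Compound 1 has no number in this assay, so it cannot be placed among the others. Compound 4 `O=C(Nc1nc2ccc(-c3cnc(Cl)c(NS(=O)(=O)c4ccc(F)cc4)c3)cc2s1)NC1CC1` differs from it in one place: cyclopropylcarbamoyl in place of propyl on a nitrogen on an aromatic ring. Among the compounds with values here, the only measured step, a 3.3-fold lower number from compound 2 to compound 3 (0.52 log units; beyond the scatter), alters a chain on the far side of a urea that compounds 2 and 3 already share; it does not test the exchange of propyl for cyclopropylcarbamoyl, so no step bears directly on the change from compound 1 to compound 4. With compound 1 unmeasured, no direction can be expected. Because compound 2 gives 1560 nM and compound 3 gives 470 nM while both carry the same urea-type linkage, compound 4 is expected to give about 900 nM, between 250 nM and 3500 nM.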

Compound 4, half-maximal inhibitory concentration: 1030 nM
Beside the measured number, compound 4's estimate is 1.1-fold (0.06 log units) below it, and the stated range covers the measured number.
By their numbers in this assay, from the lowest: compound 3; then compounds 4 and 2 (each within the scatter of the next).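

In this assay, within the data shown here, compound 1 gives "not determined" (no result reported) and so forms no new step with compound 4. As far as these compounds go, what exchanging propyl for cyclopropylcarbamoyl does to activity stays open. Nothing measured here offers an explanation for the value of compound 4.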